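Chloro-to-hydrogen change on a thiophene carboxanilide pair

The source may report more compounds than this note shows. Statements on the series, on what has been measured and on what is new or still open speak of the compounds shown alone.

Four compounds built on related cores are compared in a functional assay on SMMC-7721 cells (Homo sapiens) for inhibition, read by MTT assay; a higher number here means a weaker inhibitor, a lower number a stronger inhibitor. Compound 1 `N#Cc1c(N)sc(C(=O)Nc2ccc(Cl)cc2)c1-c1ccccc1` gives 690 nM. Compound 3 `N#Cc1c(N)sc(C(=O)Nc2ccccc2)c1-c1ccccc1` carries hydrogen in place of chloro on an aromatic carbon relative to compound 1, and in this assay compound 3 gives 5090 nM, so that the step of a 7.4-fold higher number from compound 1 to compound 3 (0.87 log units; beyond the scatter) is recorded. Compound 2 `CCOC(=O)c1c(NC(=O)CC#N)sc(C(=O)Nc2ccc(Cl)cc2)c1-c1ccccc1` differs from compound 1 in its core, and the difference between the two cores is not broken down here; in this assay compound 2 gives 730 nM, a number within the scatter of that of compound 1 and well separated from that of compound 3.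

Compound 4 `CCOC(=O)c1c(NC(=O)CC#N)sc(C(=O)Nc2ccccc2)c1-c1ccccc1` has not yet been measured. It stands to compound 2 as compound 3 stands to compound 1: the change is hydrogen in place of chloro on an aromatic carbon, and both changes sit at the same kind of place, an aromatic carbon of a six-membered aromatic ring of carbon only, para to a large group, so the change is the same. Going by the values given here, the only measured example of this change, the step of a 7.4-fold higher number from compound 1 to compound 3 (0.87 log units; beyond the scatter), gives a modest loss, and the same change is expected to behave alike on the core of compound 2. On that basis compound 4 is expected to show a step of about a 6.6-fold higher number from compound 2 to compound 4 (0.82 log units; beyond the scatter) in this assay, resting on the step of a 7.4-fold higher number from compound 1 to compound 3 (0.87 log units; beyond the scatter) and on the value of compound 2, which in this assay gives 730 nM. For compound 4 the expected value in this assay is estimated at 4800 nM, with a range from 1600 nM to 14000 nM.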

Compound 4, half-maximal inhibitory concentration: 530 nM
For compound 4 the middle estimate is 9.1-fold (0.96 log units) above the measured one; the measured number lies below the stated range.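

On the core of compound 2, the change from 4-chlorophenyl to phenyl gives in this assay a 1.4-fold lower number from compound 2 to compound 4 (0.14 log units; within the scatter), so the loss of activity seen on the core of compound 1 does not reappear and the two numbers stay within the scatter of each other. The change therefore does not carry from one core to the other as a fixed step in this series, and the two cores part clearly: the same change on two cores in this assay, a 7.4-fold higher number (0.87 log units; beyond the scatter) from compound 1 to compound 3 and a 1.4-fold lower number (0.14 log units; within the scatter) from compound 2 to compound 4, 10-fold (1.01 log units) apart, beyond the scatter of two such steps

Going by these compounds alone, what this does not show is why the two steps differ, and with only two pairs it gives no rule for predicting the step on any further core, nor does it show that chloro is without effect on the core of compound 2 in any setting beyond this cell assay.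

Open, going by these compounds, is which part of the difference between the two cores decides the outcome, and whether a bromo, methoxy or trifluoromethyl group in place of the chloro would follow the pair compound 1 and compound 3 or the pair compound 2 and compound 4. Also open, on these data alone, is whether the two steps would stay this far apart in another cell line.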